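Swapping One Small Group on Compound 1

This account rests on a few compounds, and the source may have more. Where it says the series, first, only, none or still open, it means among the compounds named here.

In a functional assay on HCT-116 cells (Homo sapiens) for inhibition, read by colorimetric assay, with a stated time of 3 days (on this read-out higher numbers stand for weaker inhibition and lower numbers for stronger inhibition), compound 1 `C/C(=N\O)C(=O)NCCCCCC(=O)Nc1ccccc1` gives > 100000 nM as its reading, which is a limit of the assay and not a number. Two other compounds give true numbers: compound 2 `COc1ccc2sc(NC(=O)CCCCCCNC(=O)C(O)(O)C(F)(F)F)nc2c1` reads 2180 nM and compound 3 `O=C(CCCCCCNC(=O)C(O)(O)C(F)(F)F)Nc1ccccc1` reads 9140 nM on the same test.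

Compound 4 `NC(=O)C(=O)NCCCCCC(=O)Nc1ccccc1` keeps the core of compound 1 and changes one place, on a carbonyl carbon, where carbamoyl enters: a group of 3 heavy atoms (1 carbon, 1 nitrogen, 1 oxygen; no ring) in place of a group of 4 heavy atoms (2 carbon, 1 nitrogen, 1 oxygen; no ring), on a carbonyl carbon sums up the swap. For the measured compounds named here, no measured step shows what this swap does, so the expectation rests on compound 1 alone, whose reading of > 100000 nM is a limit. The estimated step of a number no higher from compound 1 to compound 4 (the limit leaves the size open) is expected to stay within the usual scatter, in no particular direction. Compound 4 is estimated at 100000 nM within a range of 30000 nM to 300000 nM and is expected perhaps to end up as only a limit.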

Compound 4, half-maximal inhibitory concentration: > 100000 nM
Compound 4 ended at the assay's limit; the forecaster's own chance of this, stated with the estimate: 70%; the middle value lies on the limit itself.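

No step from compound 1 to compound 4 can be read, since both readings are limits and not numbers: the limit of > 100000 nM in this assay, at which 2 of the 4 values shown sit.

The compounds shown leave open whether putting carbamoyl on that carbonyl carbon changes inhibition at all.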